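Trimethoxyphenyl Replaces Chlorophenyl in a Weakly Active Series

A few compounds are considered here, and "the series" means these few. Any claim that something is new, unique, unknown or untested is made for them only; others in the source may bear on it.

Compound 3 `Clc1ccc(C2=NN(c3ccc(-c4ccccc4)nn3)C(c3ccc(Cl)cc3)C2)cc1` reaches only the limit > 100000 nM in a functional assay on Caco-2 cells (Homo sapiens) for antiproliferative activity, read by MTT assay, with a stated time of 24 h (a lower number here means a stronger inhibitor, a higher number a weaker inhibitor), which is not a number. Compound 1 `Clc1ccc(C2CC(c3ccccc3)=NN2c2ccc(-c3ccccc3)nn2)cc1` gives 100000 nM in this assay. Compound 2 `COc1ccc(C2CC(c3ccccc3)=NN2c2ccc(-c3ccccc3)nn2)c(OC)c1` likewise sits at the limit > 100000 nM in this assay. Compound 4 `COc1cc(C2CC(c3ccc(Cl)cc3)=NN2c2ccc(-c3ccccc3)nn2)cc(OC)c1OC` differs from compound 3 by 3,4,5-trimethoxyphenyl in place of 4-chlorophenyl on a saturated ring carbon. The nearest measured step is a number no lower from compound 1 to compound 2 (the limit leaves the size open), which also brought in a methoxy-bearing phenyl, and a number no lower from compound 1 to compound 3 (the limit leaves the size open) stayed at the limit as well, as the limit of > 100000 nM in this assay, at which 2 of the 3 values shown sit, shows. Neither step has a readable size, so no gain is expected for compound 4, and a value near the limit is estimated: 100000 nM with a range from 40000 nM to 250000 nM. The step of a number no higher from compound 3 to compound 4 (the limit leaves the size open) is expected to be small or not readable.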

Compound 4, half-maximal inhibitory concentration: > 100000 nM
Compound 4: only a limit was reported (the forecaster's own chance of this, stated with the estimate: 60%); the middle value lies on the limit itself.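

Among these compounds, compound 3 and compound 4 both rest on a limit rather than a number in this assay, so no step between them can be read. The compounds shown leave open whether 3,4,5-trimethoxyphenyl in place of 4-chlorophenyl changes the activity at all.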